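One Ring Group Swapped, Cell Tolerance in Question

The source may report more compounds than this note shows. Statements on the series, on what has been measured and on what is new or still open speak of the compounds shown alone.

In an ADME assay on MT4 cells (Homo sapiens) for cytotoxicity, read by MTT assay, with a stated time of 4 days (a lower number here means that less compound is tolerated, a higher number that more compound is tolerated), compound 1 (`Cc1ccc(-c2c(C)c(-c3ccc4c(c3C)CCCO4)c(C(OC(C)(C)C)C(=O)O)c(C)c2NS(C)(=O)=O)cc1C`) gives 24000 nM and compound 2 (`CNC(=O)Nc1c(C)c(C(OC(C)(C)C)C(=O)O)c(-c2ccc(C)c(C)c2)c(C)c1-c1ccc(C)c(C)c1`) gives 20000 nM, two values within the usual scatter of each other. Compound 3 (`Cc1ccc(-c2c(C)c(-c3ccc(C)c(C)c3)c(C(OC(C)(C)C)C(=O)O)c(C)c2NS(C)(=O)=O)cc1C`) differs from compound 1 at one place, para to a methanesulfonamido group: a group of 8 heavy atoms (8 carbon; one six-membered aromatic ring of carbon only) in place of a group of 11 heavy atoms (10 carbon, 1 oxygen; one six-membered non-aromatic ring with 1 hetero atom, one six-membered aromatic ring of carbon only), on an aromatic carbon. The entering 3,4-dimethylphenyl group also occurs in compound 2, at 20000 nM, so no step beyond the scatter is expected in this assay. The expected change is small: a 1.2-fold lower number from compound 1 to compound 3 (0.08 log units; within the scatter). For compound 3 the estimate is 20000 nM, with an expected range from 10000 nM to 40000 nM.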

Compound 3, half-maximal cytotoxic concentration: 15000 nM
Estimate against measurement, compound 3: 1.3-fold (0.12 log units) above, within the range that was stated.
By their numbers in this assay, from the lowest: compounds 3, 2 and 1 (each within the scatter of the next).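

On the aromatic carbon para to the methanesulfonamido group, 3,4-dimethylphenyl can replace the larger group with its oxygen-containing ring and leave this assay within the usual scatter (a 1.6-fold lower number from compound 1 to compound 3 (0.20 log units; within the scatter)). On the nitrogen, methylsulfonyl in place of methylcarbamoyl also stays within the scatter (a 1.3-fold lower number from compound 2 to compound 3 (0.12 log units; within the scatter)). Nothing measured here accounts for either result.

From the compounds shown here alone, whether an amine or a longer alkyl chain at that aromatic carbon would move the number beyond the scatter stays open.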